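Sulfonamide series: swapping the aryl group on the sulfonyl sulfur

This account rests on a few compounds, and the source may have more. Where it says the series, first, only, none or still open, it means among the compounds named here.

Within the data shown here, compound 2 `CC1CCN(C2CCN(S(=O)(=O)c3cnc(Cl)s3)CC2)CC1` gives 1800 nM in a functional assay on DLD-1 cells (Homo sapiens) for antiproliferative activity, read by CellTiter-Glo, with a stated time of 72 h (a higher number here means a weaker inhibitor, a lower number a stronger inhibitor), and stands highest of the two numbers so far. Compound 1 `Cc1cc(C)c(S(=O)(=O)N2CCN(C3CN4CCC3CC4)CC2)c(C)c1` gives 84 nM in this assay, a far lower number, but the two compounds differ in several places at once, so the gap cannot be tied to any one change. Compound 3 `CC1CCN(C2CCN(S(=O)(=O)c3cccc(Cl)c3)CC2)CC1` differs from compound 2 by 3-chlorophenyl in place of 2-chloro-1,3-thiazol-5-yl on a sulfonyl sulfur. Among the measured compounds shown here, no measured pair covers this change, and compounds 1 and 2 give no guide to it, so the step of no change at the digits printed from compound 2 to compound 3 (within the scatter) is expected to stay within the scatter. Compound 3 is estimated at 1800 nM, with a range from 700 nM to 4500 nM.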

Compound 3, half-maximal inhibitory concentration: > 5000 nM
Compound 3: no number, only a limit (the forecaster's own chance of this, stated with the estimate: 5%); middle value at least 2.7-fold (0.44 log units) from the limit.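

Among these compounds, on this sulfonyl sulfur the aryl group is not interchangeable in this assay: 3-chlorophenyl in place of 2-chloro-1,3-thiazol-5-yl gives an at least 2.7-fold higher number from compound 2 to compound 3 (0.44 log units; beyond the scatter), the only step at a single place so far. Compound 3 carries a limit and not a number, so this step has a floor but no measured size: the limit of > 5000 nM in this assay, at which 1 of the 3 values shown sits.

A single pair cannot separate the effect of the ring from that of its hetero atoms or its chlorine. A pyridyl group or an unsubstituted phenyl on the same sulfur would address that question.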